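The compounds below may be only part of what the source reports. "The series", "measured", "known", "first", "only" and "open" are said of these compounds alone.

Working notes on the series. Among the measured compounds shown here, compound 3 `CC(C)OC(=O)C1=CN(C(=O)C2CCCCC2)CC(C)(C)c2cc(C#N)[nH]c21` gives 124% in an assay on HEK293 cells for agonist activity at Bile acid receptor (Homo sapiens), read by a luciferase reporter (on this read-out higher numbers stand for larger maximal responses and lower numbers for smaller maximal responses), the highest of the three numbers so far, although its steps to the other two members stay inside the scatter. Compound 1 `CC(C)OC(=O)C1=CN(C(=O)c2ccc(C#N)cc2)CC(C)(C)c2cc(C#N)[nH]c21` gives 116% and compound 2 `CC(C)OC(=O)C1=CN(C(=O)c2cccs2)CC(C)(C)c2cc(C#N)[nH]c21` gives 114% in this assay.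

Compound 4 `CC(C)OC(=O)C1=CN(C(=O)c2ccc(F)c(F)c2)CC(C)(C)c2cc(C#N)[nH]c21` is the next member, differing from compound 3 by 3,4-difluorophenyl in place of cyclohexyl on a carbonyl carbon. For the measured compounds named here, the steps that bear on this change are the two in which cyclohexyl on the carbonyl carbon replaces a six-membered aromatic ring or a thiophen-2-yl: a number 8 percentage points higher from compound 1 to compound 3 (within the scatter) and a number 10 percentage points higher from compound 2 to compound 3 (within the scatter), both within the scatter. A step back to an aromatic ring on that carbonyl carbon is therefore expected to move this assay by nothing beyond the scatter, with a slight lean downward toward the numbers of compound 1 and compound 2.

Compound 4 is estimated at 117%, with a range from 102% to 132%; the expected step is a number 7 percentage points lower from compound 3 to compound 4 (within the scatter).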

Compound 4, largest response reached (reported as efficacy), in percent of the reference or control that the assay uses: 121%
Compound 4: the middle estimate sits 4 percentage points below what was measured; the range from low to high includes it.
By their numbers in this assay, from the lowest: compounds 2, 1, 4 and 3 (each within the scatter of the next).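

On the carbonyl carbon, the change from a saturated ring to a fluorinated aromatic ring gives (a number 3 percentage points lower from compound 3 to compound 4 (within the scatter)), so cyclohexyl and 3,4-difluorophenyl cannot be told apart in this assay. The comparisons with the other aromatic groups read the same way, with thiophen-2-yl replaced (a number 7 percentage points higher from compound 2 to compound 4 (within the scatter)) and 4-cyanophenyl replaced (a number 5 percentage points higher from compound 1 to compound 4 (within the scatter)), which extends the flat picture at this position to a fourth group. No measurement available here explains this flat picture.

From the compounds shown here alone, whether the maximal response stays this flat with a carboxylic acid or an amine on the ring remains open, as does the effect of a short chain such as methyl in place of the ring. These numbers give maximal response only and say nothing about the concentrations needed to reach it.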